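The source may hold more compounds than are shown below. What is called first, only, known or untested is meant among the compounds shown, and "the series" means these compounds.

Compound 1 `CN(C)CCNc1nc(-c2ccc(NC(=O)Nc3ccccc3F)cc2)nc2ccsc12` gives 510 nM in a functional assay on HT-29 cells (Homo sapiens) for cytotoxicity, read by MTT assay, with a stated time of 72 h; a higher number here means a weaker inhibitor, a lower number a stronger inhibitor.
Compound 2 `CN(C)CCNc1nc(-c2ccc(NC(=O)Nc3ccc(Cl)cc3)cc2)nc2ccsc12` gives 95 nM in this assay.
Compound 3 `CN(C)CCNc1nc(-c2ccc(NC(=O)Nc3ccccc3Cl)cc2)nc2ccsc12` gives 310 nM in this assay.

Among the three measured compounds, compound 1 stands at the highest number. Its nearest neighbour is compound 3, reached by a 1.6-fold lower number from compound 1 to compound 3 (0.22 log units; within the scatter), a step within the scatter. The furthest is compound 2, reached by a 5.4-fold lower number from compound 1 to compound 2 (0.73 log units; beyond the scatter). Between the two chlorinated analogues the gap is a 3.3-fold higher number from compound 2 to compound 3 (0.51 log units; beyond the scatter).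

Compound 4 `CCN(CC)CCCNc1nc(-c2ccc(NC(=O)Nc3ccccc3F)cc2)nc2ccsc12` keeps the shared core and the urea part of compound 1 unchanged and differs only on the side chain: (diethylamino)methyl in place of dimethylamino on a saturated chain carbon, two bonds along the chain from a nitrogen on an aromatic ring. The three measured steps all alter the phenyl ring on the urea, while the side chain is the same in compounds 1, 2 and 3, so none of them bears on this change. The data therefore give no ground for expecting a shift beyond the scatter in either direction, and the step from compound 1 is expected to be about a 1.0-fold lower number from compound 1 to compound 4 (0.01 log units; within the scatter). Going by the values given here, for compound 4 the expected value in this assay is 500 nM, with a range from 180 nM to 1400 nM, kept wide since no measured step tests the side chain.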

Compound 4, half-maximal inhibitory concentration: 550 nM
Estimate against measurement, compound 4: 1.1-fold (0.04 log units) below, and the stated range covers the measured number.
By their numbers in this assay, from the lowest: compound 2; then compounds 3, 1 and 4 (each within the scatter of the next).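

Going by these compounds alone, the side chain was the same in compounds 1, 2 and 3, so compound 4 gives the first reading at this position. In this assay, (diethylamino)methyl in place of dimethylamino, on a saturated chain carbon, two bonds along the chain from a nitrogen on an aromatic ring, gives a 1.1-fold higher number from compound 1 to compound 4 (0.03 log units; within the scatter), so this larger group, with the same count of hydrogen-bond donors and acceptors, leaves the number within the scatter when the 2-fluorophenyl urea is held fixed. No independent measurement is available to explain this result.

The step alters the chain length and the groups on the terminal nitrogen together, so the compounds shown do not separate the two, and the side-chain change is read only with the 2-fluorophenyl urea, leaving open whether it would hold with the 4-chlorophenyl urea of compound 2, at 95 nM. Also open, as far as these compounds go, is how the number would respond to a morpholine or a piperidine at the end of the chain, to a primary amine there, or to a carboxylic acid in place of the amine.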